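The compounds below may be only part of what the source reports. "The series", "measured", "known", "first", "only" and "open" are said of these compounds alone.

Three compounds of the series carry numbers in an assay on CHO cells for displacement of a labelled ligand from adenosine receptor A3 (Homo sapiens), read by scintillation counting, with a stated time of 45 min, tested at 1 uM, in the presence of a further agent that is not named here; on this read-out lower numbers stand for less inhibition and higher numbers for more inhibition at the one concentration tested (going by the name of the read-out). Compound 1 `CCCn1c(=O)[nH]c2nc(-c3ccc(S(=O)(=O)N4CCN(c5ccc(Br)cc5)CC4)cc3)[nH]c2c1=O` gives 29%. Compound 2 `CCCn1c(=O)[nH]c2nc(-c3ccc(S(=O)(=O)N4CCN(C)CC4)cc3)[nH]c2c1=O` gives 7%, and compound 3 `CCCn1c(=O)[nH]c2nc(-c3ccc(S(=O)(=O)N4CCN(Cc5ccc(Br)c(F)c5)CC4)cc3)[nH]c2c1=O` gives 27%. Compound 3 thus stands second highest of the three, nearest to compound 1 and farthest from compound 2. The steps among them: a number 22 percentage points lower from compound 1 to compound 2 (beyond the scatter), a number 2 percentage points lower from compound 1 to compound 3 (within the scatter), and a number 20 percentage points higher from compound 2 to compound 3 (beyond the scatter).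

Compound 4 `CCCn1c(=O)[nH]c2nc(-c3ccc(S(=O)(=O)N4CCN(c5ccc(I)cc5)CC4)cc3)[nH]c2c1=O` has not been measured. It differs from compound 3 by 4-iodophenyl in place of 4-bromo-3-fluorobenzyl on an amine nitrogen in a ring. Going by the values given here, the measured step that bears on this is the one from compound 1 to compound 3, in which 4-bromo-3-fluorobenzyl replaced 4-bromophenyl on the amine nitrogen in the ring and the read-out moved by a number 2 percentage points lower from compound 1 to compound 3 (within the scatter), within the scatter. Among the compounds with values here, compound 4 returns to a halogen-bearing phenyl set directly on that nitrogen, with iodine in place of bromine; the only measured example of that kind is compound 1 at 29%. The drop seen with the methyl of compound 2, a number 22 percentage points lower from compound 1 to compound 2 (beyond the scatter), involves a far smaller group and does not apply here. No step beyond the scatter is expected, a number 1 percentage points higher from compound 3 to compound 4 (within the scatter). Compound 4 is estimated at 28%, between 15% and 42%.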

Compound 4, a percentage reported as inhibition, at one concentration (the size of the read-out at that concentration, not a potency): 36%
The estimate for compound 4 lay 8 percentage points below the measured number; measured number inside the range.
By their numbers in this assay, from the lowest: compound 2; then compounds 3, 1 and 4 (each within the scatter of the next).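

Iodo in place of bromo on an aromatic carbon gives a number 7 percentage points higher from compound 1 to compound 4 (within the scatter) in this assay and so stays within the scatter, which is the first reading of a halogen exchange at this place. 4-iodophenyl in place of 4-bromo-3-fluorobenzyl gives a number 9 percentage points higher from compound 3 to compound 4 (within the scatter) and also stays within the scatter, whereas 4-iodophenyl in place of methyl gives a number 29 percentage points higher from compound 2 to compound 4 (beyond the scatter) and lies beyond it, so compound 1, compound 3 and compound 4 all stand apart from compound 2 by more than the scatter, and none of the three can be told from the others. Nothing measured here speaks to why the halogen-bearing groups stand apart from methyl.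

Open, on these data alone, is whether the halogen matters at all, since an unsubstituted phenyl, a 4-methoxyphenyl or a 4-chlorophenyl on the same amine nitrogen could either hold the read-out of these three groups or fall towards that of the methyl. Equally open, as far as these compounds go, is how a benzoyl group or a longer chain ending in a phenyl would read at this nitrogen, and whether any group here can rise clear of the scatter around these three.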